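A few compounds are considered here, and "the series" means these few. Any claim that something is new, unique, unknown or untested is made for them only; others in the source may bear on it.

Compound 1 `CN(C(=O)CCc1ccccc1)c1ccc2[nH]c(-c3n[nH]c4ccccc34)cc2n1`: 11200 nM
Compound 2 `COc1ccc(C(=O)N(C)c2ccc3[nH]c(-c4n[nH]c5ccccc45)cc3n2)cc1`: 29500 nM

Within the data shown here, in a functional assay on HCT-116 cells (Homo sapiens) for antiproliferative activity, read by MTT assay, with a stated time of 72 h (a higher number here means a weaker inhibitor, a lower number a stronger inhibitor), compound 2 stands highest of the two numbers measured; its only neighbour is compound 1, reached through the step of a 2.6-fold higher number from compound 1 to compound 2 (0.42 log units; beyond the scatter). Compound 3 `CN(c1ccc2[nH]c(-c3n[nH]c4ccccc34)cc2n1)S(=O)(=O)c1ccc(Br)cc1` differs from compound 2 by (4-bromophenyl)sulfonyl in place of (4-methoxyphenyl)carbonyl on a nitrogen on an aromatic ring. Among the measured compounds shown here, the one measured step changed only the group on the carbonyl, so nothing measured here bears on exchanging the carbonyl itself for a sulfonyl, and no direction is established. Compound 3 is therefore expected to stay close to compound 2, with the estimated step of a 1.2-fold lower number from compound 2 to compound 3 (0.07 log units; within the scatter) not beyond the scatter. Compound 3 is estimated at 25000 nM, within a range from 7000 nM to 90000 nM.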

Compound 3, half-maximal inhibitory concentration: 9850 nM
For compound 3 the middle estimate is 2.5-fold (0.40 log units) above the measured one; measured number inside the range.
By their numbers in this assay, from the lowest: compounds 3 and 1 (each within the scatter of the next); then compound 2.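

In this assay the nitrogen on an aromatic ring accepts a sulfonyl without loss, giving a 3.0-fold lower number from compound 2 to compound 3 (0.48 log units; beyond the scatter) against the (4-methoxyphenyl)carbonyl and a 1.1-fold lower number from compound 1 to compound 3 (0.06 log units; within the scatter) against the phenethylcarbonyl. The first of these steps swaps carbonyl for sulfonyl and methoxy for bromine together, so the share of each cannot be told. No measurement at hand explains the result.

Still open, from the compounds shown here alone, is how a sulfonyl carrying 4-methoxyphenyl would compare with compound 3. Also open, going by these compounds, is whether a small group such as acetyl, or an amine-bearing chain, would serve on this nitrogen.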